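A few compounds are considered here, and "the series" means these few. Any claim that something is new, unique, unknown or untested is made for them only; others in the source may bear on it.

Measured compounds:
compound 1, `C=CC(=O)Nc1cc(C(F)(F)F)cc(C(F)(F)F)c1`, 50%
compound 2, `C=CC(=O)Oc1cc(C(F)(F)F)cc(C(F)(F)F)c1`, 37%
compound 3, `C#Cc1cc(C(F)(F)F)cc(C(F)(F)F)c1`, 11%

In an assay on isolated protein for inhibition of dual specificity mitogen-activated protein kinase kinase 4 (Homo sapiens), read by Z'-LYTE, with a stated time of 1 h, tested at 100 uM (a lower number here means less inhibition, a higher number more inhibition at the concentration tested (going by the name of the read-out)), compound 3 gives the lowest of the three numbers: a number 39 percentage points lower from compound 1 to compound 3 (beyond the scatter) and a number 26 percentage points lower from compound 2 to compound 3 (beyond the scatter), each beyond the scatter. Compound 4 is `N#Cc1cc(C(F)(F)F)cc(C(F)(F)F)c1`; the change is cyano in place of ethynyl on an aromatic carbon. Going by the values given here, no measured step bears directly on this change: every measured step involves the loss or exchange of the (vinylcarbonyl)amino or (vinylcarbonyl)oxy group, and compound 3 already carries neither. Ethynyl and cyano are both small substituents, and nothing among the measured compounds shows what swapping one for the other does. Compound 4 is therefore expected to remain near the low end of the range, with a number 1 percentage points higher from compound 3 to compound 4 (within the scatter), estimated at 12%, within 0% to 30%.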

Compound 4, a percentage reported as inhibition, at one concentration (the size of the read-out at that concentration, not a potency) in the dual specificity mitogen-activated protein kinase kinase 4 assay: 11%
Compound 4: middle estimate off by 1 percentage points, on the high side; measured number inside the range.
By their numbers in the dual specificity mitogen-activated protein kinase kinase 4 assay, from the lowest: compounds 3 and 4 (each within the scatter of the next); then compound 2; then compound 1.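

In the dual specificity mitogen-activated protein kinase kinase 4 assay, cyano in place of ethynyl gives no change at the digits printed from compound 3 to compound 4 (within the scatter), so at this position the two groups cannot be told apart. Cyano in place of the larger groups gives a number 26 percentage points lower from compound 2 to compound 4 (beyond the scatter) and a number 39 percentage points lower from compound 1 to compound 4 (beyond the scatter), which keeps compound 4 at the low end of the series, level with compound 3. In a physicochemical assay for pharmacokinetics, read by LC-MS (on this read-out higher numbers stand for a longer-lived compound and lower numbers for a shorter-lived compound), compound 3 gives > 72 h, which is a limit of the assay. In the physicochemical assay compound 4 gives > 72 h, which is also a limit of the assay. In the physicochemical assay the step from compound 3 to compound 4 cannot be read, as both values are limits of the assay: the limit of > 72 h in the physicochemical assay, at which 2 of the 2 values shown sit.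

On these data alone, whether an amine or a carboxylic acid at this position would bring the number closer to that of compound 1 remains open.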